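Replacing 2-hydroxyethyl with cyano: an expected clearance

The source may hold more compounds than are shown below. What is called first, only, known or untested is meant among the compounds shown, and "the series" means these compounds.

In an ADME assay on microsomes (Homo sapiens) for metabolic stability (on this read-out higher numbers stand for fast clearance and lower numbers for slow clearance), compound 1 (`Cc1cc(C(F)(F)F)c2cccc(OCc3c(Cl)ccc(S(=O)(=O)N4CCCC4)c3Cl)c2n1`) gives 233 mL/min/kg, and compound 2 (`Cc1cc(C(F)(F)F)c2cccc(OCc3c(Cl)ccc(S(=O)(=O)N4CCCCC4)c3Cl)c2n1`) gives 233 mL/min/kg. Compound 3 (`Cc1cc(C(F)(F)F)c2cccc(OCc3c(Cl)ccc(S(=O)(=O)N4CCC(CCO)CC4)c3Cl)c2n1`) gives 367 mL/min/kg, which lies within the scatter of both others. Compound 4 (`Cc1cc(C(F)(F)F)c2cccc(OCc3c(Cl)ccc(S(=O)(=O)N4CCC(C#N)CC4)c3Cl)c2n1`) has cyano in place of 2-hydroxyethyl on a saturated ring carbon, three ring bonds from the ring nitrogen (cyano in place of 2-hydroxyethyl on a saturated ring carbon). The closest evidence is the step that puts 2-hydroxyethyl in place of hydrogen on a saturated ring carbon, which gave a 1.6-fold higher number from compound 2 to compound 3 (0.20 log units; within the scatter). Changes to the group on the sulfonyl sulfur gave no change at the digits printed from compound 1 to compound 2 (within the scatter) and a 1.6-fold higher number from compound 1 to compound 3 (0.20 log units; within the scatter). Within the data shown here, none of these steps goes beyond the scatter, although no measured compound carries cyano, so the evidence for this group is indirect. No shift beyond the scatter is therefore expected in this assay, and the expected move is a 1.5-fold lower number from compound 3 to compound 4 (0.18 log units; within the scatter). For compound 4 the estimated clearance is 240 mL/min/kg, with an expected range of 130 mL/min/kg to 420 mL/min/kg.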

Compound 4, clearance: 433 mL/min/kg
Compound 4: the middle estimate sits 1.8-fold (0.26 log units) below what was measured, and the stated range ends below it.
By their numbers in this assay, from the lowest: compounds 1, 2, 3 and 4 (each within the scatter of the next).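

In this assay, putting cyano, with 0 hydrogen-bond donors, in place of 2-hydroxyethyl on this saturated ring carbon gives a 1.2-fold higher number from compound 3 to compound 4 (0.07 log units; within the scatter) and so stays inside the usual variation. Set against the compounds without a substituent on the ring, the cyano compound gives a 1.9-fold higher number from compound 2 to compound 4 (0.27 log units; within the scatter) and a 1.9-fold higher number from compound 1 to compound 4 (0.27 log units; within the scatter), so all four sulfonyl groups shown, now including a substituent without a hydrogen-bond donor, lie within the scatter of one another. The data shown offer no measurement that would explain these numbers.

As far as these compounds go, whether any group on this carbon can move clearance beyond the scatter stays open, for example an amine, a carboxylic acid or a longer chain ending in hydroxyl. Also open, from the compounds shown here alone, is whether cyano would give the same picture on the pyrrolidine ring.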